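Aryl sulfonamide series: from dimethylphenyl to chlorophenyl

The source may hold more compounds than are shown below. What is called first, only, known or untested is meant among the compounds shown, and "the series" means these compounds.

Measured compounds:
compound 1 `COc1ccc(NS(=O)(=O)c2ccc(N3CCNC3=O)cc2)cc1` gives 580 nM
compound 2 `COc1ccccc1NS(=O)(=O)c1ccc(N2CCNC2=O)cc1` gives 300 nM
compound 3 `Cc1cc(C)cc(NS(=O)(=O)c2ccc(N3CCNC3=O)cc2)c1` gives 63 nM

All three share the same core and differ only in the aryl group on the sulfonamide nitrogen, and they were all tested in a functional assay on M21 cells (Homo sapiens) for antiproliferative activity, read by sulforhodamine B assay, with a stated time of 48 h; on this read-out lower numbers stand for stronger inhibition and higher numbers for weaker inhibition. Compound 3 stands lowest of the three numbers: its nearest neighbour is compound 2, a 4.8-fold lower number from compound 2 to compound 3 (0.68 log units; beyond the scatter), and the furthest is compound 1, a 9.2-fold lower number from compound 1 to compound 3 (0.96 log units; beyond the scatter). Between compound 1 and compound 2 the step is a 1.9-fold lower number from compound 1 to compound 2 (0.29 log units; within the scatter).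

The next compound is compound 4 `O=C1NCCN1c1ccc(S(=O)(=O)Nc2cccc(Cl)c2)cc1`. Its change from compound 3 is 3-chlorophenyl in place of 3,5-dimethylphenyl on a sulfonamide nitrogen. Within the data shown here, no measured step covers a chlorophenyl group, so only the general lesson of the measured steps applies: altering the aryl group at this position moved the read-out by the modest amounts seen in a 4.8-fold lower number from compound 2 to compound 3 (0.68 log units; beyond the scatter) and a 9.2-fold lower number from compound 1 to compound 3 (0.96 log units; beyond the scatter), and compound 3 carries the pattern that reached the lowest number. Replacing it by 3-chlorophenyl is therefore expected to cost some of that, with a step of roughly a 2.4-fold higher number from compound 3 to compound 4 (0.38 log units; beyond the scatter). The estimate for compound 4 in this assay is 150 nM, within a range from 50 nM to 500 nM.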

Compound 4, half-maximal inhibitory concentration: 25 nM
The estimate for compound 4 lay 6.0-fold (0.78 log units) above the measured number, outside the stated range (below it).
By their numbers in this assay, from the lowest: compound 4; then compound 3; then compounds 2 and 1 (each within the scatter of the next).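

In this assay, the 3-chlorophenyl group of compound 4 went past the pattern that had held the lowest number, with a 2.5-fold lower number from compound 3 to compound 4 (0.40 log units; beyond the scatter), so the 3,5-dimethylphenyl group did not mark the floor at this position, and a single chlorine could stand in for the two methyl groups without any loss. Against the two methoxyphenyl compounds the change gives a 12-fold lower number from compound 2 to compound 4 (1.08 log units; beyond the scatter) and a 23-fold lower number from compound 1 to compound 4 (1.37 log units; beyond the scatter), the first large steps in the set, which shows that the aryl group on the sulfonamide nitrogen alone can span a much wider range than the modest steps seen earlier suggested. No evidence is available that bears on why this group gives the lowest number of the four.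

The compounds shown leave open whether the chlorine itself matters or simply the presence of one substituent, a question that a plain phenyl, a phenyl carrying one methyl group, or a bromophenyl or fluorophenyl would help to settle. On these data alone, all four compounds also keep the same shared core and the same sulfonamide link, so the effect of any change there, such as a methyl group on the sulfonamide nitrogen, remains unknown.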